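Compound 1 and Its Hydroxy Analogue

This account rests on a few compounds, and the source may have more. Where it says the series, first, only, none or still open, it means among the compounds named here.

Among the measured compounds shown here, in a functional assay on CCRF-CEM cells (Homo sapiens) for antiproliferative activity, read by fluorescence and resazurin assay, with a stated time of 48 h (on this read-out lower numbers stand for stronger inhibition and higher numbers for weaker inhibition), compound 1 (`CCOc1ccc2nc(Cl)c(/C=N/NC(=O)c3cc4ccccc4oc3=O)cc2c1`) gives 6320 nM and so holds the lower of the two numbers measured so far. For the measured compounds named here, compound 2 (`CCOc1ccc2nc(Cl)c(/C=N/NC(=O)c3cc4cc(Br)ccc4oc3=O)cc2c1`) gives 12900 nM and is its only measured neighbour. Compound 3 (`CCOc1ccc2nc(Cl)c(/C=N/NC(=O)c3cc4ccc(O)cc4oc3=O)cc2c1`) has not yet been measured. It carries hydroxy in place of hydrogen on an aromatic carbon of the core of compound 1.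

Going by the values given here, one measured step bears on this change, and only indirectly: bromo in place of hydrogen on an aromatic carbon gives a 2.0-fold higher number from compound 1 to compound 2 (0.31 log units; beyond the scatter) and is modest in size. Among the compounds with values here, it involves a different group, and no measured compound carries a hydroxy group, so it offers weak guidance. In this assay a small upward move is therefore expected, possibly none beyond the scatter, and a step as large as that to compound 2 remains possible. The expected outcome is a 1.2-fold higher number from compound 1 to compound 3 (0.07 log units; within the scatter) as a small step. Compound 3 is estimated at 7500 nM with an expected range from 3000 nM to 17000 nM as its likely span.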

Compound 3, half-maximal inhibitory concentration: 17100 nM
Compound 3: the middle estimate sits 2.3-fold (0.36 log units) below what was measured, outside the stated range (above it).
By their numbers in this assay, from the lowest: compound 1; then compounds 2 and 3 (each within the scatter of the next).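

In this assay, placing a hydroxy group on this aromatic carbon of the core of compound 1 gives a 2.7-fold higher number from compound 1 to compound 3 (0.43 log units; beyond the scatter), so this position does not tolerate the change without a loss beyond the scatter, and a single added oxygen is enough to produce it. Until now, the only substituent evidence was a 2.0-fold higher number from compound 1 to compound 2 (0.31 log units; beyond the scatter), which came from bromo at a different carbon; the two steps now point the same way, and among these three compounds, none goes against the pattern that the unsubstituted compound 1 holds the lowest number. Nothing measured here gives a reason for the rise on adding hydroxy.

The compounds shown leave open whether the rise belongs to hydroxy itself or would follow any group on this carbon, a question that a methoxy group, an amine or a fluorine in the same place could address. They also leave open whether any replacement for hydrogen on this ring can bring the number below that of compound 1, which on present evidence remains the lowest of the three.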